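This account rests on a few compounds, and the source may have more. Where it says the series, first, only, none or still open, it means among the compounds named here.

The account starts from compound 1 `CCCCCC(=O)Oc1ccc(C(=O)C2=C3OC(C)(C)[C@@H](CC=C(C)C)C[C@@]34C[C@@H](CC=C(C)C)C(C)(C)[C@H]3CCC(C)(C)O[C@]34OC2=O)cc1OC(=O)CCCCC`, whose antiproliferative potency was measured in a functional assay on HEL cells (Homo sapiens) for antiproliferative activity, read by MTT assay, with a stated time of 72 h; on this read-out lower numbers stand for stronger inhibition and higher numbers for weaker inhibition. In this assay, for the measured compounds named here, compound 1 gives 19900 nM, the only numerical value among the three measured compounds. Compound 2 `COc1ccc(C(=O)Oc2ccc(C(=O)C3=C4OC(C)(C)[C@@H](CC=C(C)C)C[C@@]45C[C@@H](CC=C(C)C)C(C)(C)[C@H]4CCC(C)(C)O[C@]45OC3=O)cc2OC(=O)c2ccc(OC)cc2)cc1` reaches only a limit of the assay, > 20000 nM. Compound 3 `CC(C)=CC[C@H]1C[C@]23C[C@@H](CC=C(C)C)C(C)(C)[C@H]4CCC(C)(C)O[C@]42OC(=O)C(C(=O)c2ccc(OC(=O)c4ccc(F)cc4)c(OC(=O)c4ccc(F)cc4)c2)=C3OC1(C)C` likewise reaches only a limit, > 20000 nM. Two of the three measurements therefore sit at the limit of > 20000 nM in this assay, at which 2 of the 3 values shown sit, and compound 1 stands just inside it. Compound 4 `CCCCCC(=O)Oc1cc(C(=O)C2=C3OC(C)(C)[C@@H](CC=C(C)C)C[C@@]34C[C@@H](CC=C(C)C)C(C)(C)[C@H]3CCC(C)(C)O[C@]34OC2=O)ccc1O` is not yet measured; it differs from compound 1 in one place: hydrogen in place of pentylcarbonyl on an oxygen on an aromatic ring. Going by the values given here, with no measured step of this kind available, the change is expected to stay within the usual scatter, perhaps a small gain, estimated as a 1.3-fold lower number from compound 1 to compound 4 (0.12 log units; within the scatter). Compound 4 is thus expected to give about 15000 nM, between 5000 nM and 30000 nM.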

Compound 4, half-maximal inhibitory concentration: 9530 nM
The estimate for compound 4 lay 1.6-fold (0.20 log units) above the measured number, and the stated range covers the measured number.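

For the compounds shown here, the change from (pentylcarbonyl)oxy to hydroxy gives a 2.1-fold lower number from compound 1 to compound 4 (0.32 log units; beyond the scatter), the first step that can be read in this assay. It shows that this position responds to the change and that losing one pentylcarbonyl group does not cost potency. The gain is modest and starts close to the limit of the assay: the limit of > 20000 nM in this assay, at which 2 of the 4 values shown sit.

The compounds shown leave open whether removing the remaining pentylcarbonyl group would bring a further change. They also leave open how a methyl ether or an amine in place of the hydroxy would read.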